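Sulfonylquinoxaline anilines: bromo for methyl on the sulfonyl ring

The source may report more compounds than this note shows. Statements on the series, on what has been measured and on what is new or still open speak of the compounds shown alone.

Measured so far:
- compound 1 `COc1ccc(Nc2nc3ccccc3nc2S(=O)(=O)c2ccc(C)cc2)cc1`: > 50000 nM
- compound 2 `Cc1ccc(S(=O)(=O)c2nc3ccccc3nc2Nc2cccc(N)c2)cc1`: 2390 nM
- compound 3 `Cc1ccc(S(=O)(=O)c2nc3ccccc3nc2Nc2cccc(O)c2)cc1`: 3810 nM

In a functional assay on HCT-116 cells (Homo sapiens) for cytotoxicity, read by MTT assay, with a stated time of 72 h (on this read-out lower numbers stand for stronger inhibition and higher numbers for weaker inhibition), compound 1 gives only a limit, > 50000 nM. Compound 2 gives 2390 nM and compound 3 gives 3810 nM in this assay. Compound 3 thus holds the highest of the two actual numbers, with compound 2 nearest: a 1.6-fold higher number from compound 2 to compound 3 (0.20 log units; within the scatter). The two large steps seen so far, an at least 20-fold lower number from compound 1 to compound 2 (1.32 log units; beyond the scatter) and an at least 13-fold lower number from compound 1 to compound 3 (1.11 log units; beyond the scatter), both concern the group on the nitrogen of the shared core.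

Compound 4 `O=S(=O)(c1ccc(Br)cc1)c1nc2ccccc2nc1Nc1cccc(O)c1` differs from compound 3 elsewhere: bromo in place of methyl on an aromatic carbon. For the measured compounds named here, no measured step touches this position, so nothing supports a directional expectation for this change; the working expectation is a step within the scatter, a 1.0-fold lower number from compound 3 to compound 4 (0.00 log units; within the scatter). Compound 4 is therefore estimated at 3800 nM in this assay, with a range of 1300 nM to 11000 nM, the width reflecting that this is an untested position.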

Compound 4, half-maximal inhibitory concentration: 540 nM
For compound 4 the middle estimate is 7.0-fold (0.85 log units) above the measured one; measured number outside the range, below it.
By their numbers in this assay, from the lowest: compound 4; then compounds 2 and 3 (each within the scatter of the next). At a limit, above all of these: compound 1.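

Swapping 4-methylphenyl for 4-bromophenyl gives the only step measured at this position, and in this assay it is beyond the scatter: a 7.1-fold lower number from compound 3 to compound 4 (0.85 log units; beyond the scatter). The earlier steps shown here beyond the scatter all concerned the group on the nitrogen of the shared core, so this pair shows that the read-out also responds to the group on the sulfonyl, even when one heavy atom replaces one heavy atom and the counted hydrogen-bond donors and acceptors stay the same. Nothing at hand gives a cause for this step.

From the compounds shown here alone, the effect rests on a single pair carrying 3-hydroxyphenyl, so whether bromo does the same alongside the 3-aminophenyl of compound 2 remains open. Going by these compounds, how chloro, methoxy or a carboxylic acid would read at this position is also open, so no trend across groups can be drawn here.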